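Hydrazone aryl exchange on the shared triazine core

The compounds below may be only part of what the source reports. "The series", "measured", "known", "first", "only" and "open" are said of these compounds alone.

Compound 1, `NS(=O)(=O)c1ccc(Nc2nc(N/N=C/c3ccc(C(F)(F)F)cc3)nc(Nc3ccccc3)n2)cc1`, in a functional assay on SF-295 cells (Homo sapiens) for inhibition, read by sulforhodamine B assay, with a stated time of 48 h (on this read-out higher numbers stand for lower toxicity in this test and lower numbers for higher toxicity in this test), gives 8630 nM.
Compound 2, `Cc1nn(-c2ccccc2)cc1/C=N/Nc1nc(Nc2ccccc2)nc(Nc2ccc(S(N)(=O)=O)cc2)n1`, in this assay gives > 100000 nM, which is a limit of the assay and not a number.

Compound 2 therefore stands only at a bound of this assay; no number for it is known. Within the data shown here, the single measured step, an at least 11-fold higher number from compound 1 to compound 2 (1.06 log units; beyond the scatter), is itself bounded by the limit of > 100000 nM in this assay, at which 1 of the 2 values shown sits.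

Compound 3, `NS(=O)(=O)c1ccc(Nc2nc(N/N=C/c3ccccn3)nc(Nc3ccccc3)n2)cc1`, differs from compound 2 in pyridin-2-yl in place of 3-methyl-1-phenyl-1H-pyrazol-4-yl on a carbon with a double bond to nitrogen. Among the measured compounds shown here, no measured step covers this pair directly. What is known is that exchanging the aryl group on the carbon with a double bond to nitrogen moves the number by a large amount, and compound 3 carries again a six-membered aromatic ring, as compound 1 does with its 8630 nM. Compound 3 is therefore expected to return toward a lower number than compound 2, a step of about an at least 3.3-fold lower number from compound 2 to compound 3 (0.52 log units; beyond the scatter). The estimate for compound 3 in this assay is 30000 nM, with a range from 6000 nM to 100000 nM; a further limit value is a real possibility.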

Compound 3, concentration lethal to 50% of the cells: > 100000 nM
Compound 3: no number, only a limit; the forecaster's own chance of this, stated with the estimate: 35%; middle value at least 3.3-fold (0.52 log units) away from the limit.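

Replacing 4-(trifluoromethyl)phenyl with pyridin-2-yl on a carbon with a double bond to nitrogen gives an at least 11-fold higher number from compound 1 to compound 3 (1.06 log units; beyond the scatter), so a six-membered aromatic ring at this place does not by itself keep the number near that of compound 1. Two different groups, 3-methyl-1-phenyl-1H-pyrazol-4-yl and pyridin-2-yl, now both end at a limit of this assay, and among the compounds shown only compound 1 has a readable number. The step from compound 2 to compound 3 cannot be read, and the size of the step from compound 1 to compound 3 is only a bound, because of the assay ceiling: the limit of > 100000 nM in this assay, at which 2 of the 3 values shown sit.

As far as these compounds go, how far compound 2 and compound 3 lie past the limit remains open, as does any order between them. Also open, from the compounds shown here alone, is whether the number of compound 1 goes with its trifluoromethyl group or with the benzene ring that carries it; a plain phenyl, a 4-aminophenyl or a 4-carboxyphenyl group on this carbon would bear on that question.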